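This account rests on a few compounds, and the source may have more. Where it says the series, first, only, none or still open, it means among the compounds named here.

Measured so far:
- compound 1, `CN(C)c1ccc(C(=O)Nc2cccc(NC(=O)COc3ccc4c(c3)OCCO4)c2)cc1`: > 10000 nM
- compound 2, `N#Cc1ccc(C(=O)Nc2cccc(NC(=O)COc3ccc4c(=O)ccoc4c3)c2)cc1`: 15 nM

In an assay on isolated protein for inhibition of Rho-associated protein kinase 2 (Homo sapiens), read by scintillation counting, radiometric assay and 33P incorporation, with a stated time of 40 min, in the presence of a further agent that is not named here (a higher number here means a weaker inhibitor, a lower number a stronger inhibitor), compound 1 gives only > 10000 nM, which is a limit of the measurement and not a number. Among the measured compounds shown here, compound 2 gives 15 nM in this assay and is the only compound of the pair with a numerical value; the other value sits at the limit of > 10000 nM in this assay, at which 1 of the 2 values shown sits. Compound 1 and compound 2 differ in more than one place, so the two values show no more than that one is a limit and the other a number.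

Not yet measured is compound 3, `Cc1cc(C(=O)Nc2cccc(NC(=O)COc3ccc4c(=O)ccoc4c3)c2)no1`. Against compound 2 the change is 5-methyl-1,2-oxazol-3-yl in place of 4-cyanophenyl on a carbonyl carbon. The rest of the structure, including the shared core, is unchanged. For the measured compounds named here, no step between measured compounds exists here for this kind of change, so the expectation rests on compound 2 alone. A modest step toward a weaker inhibitor is expected, with the change from compound 2 to compound 3 estimated at a 4.0-fold higher number from compound 2 to compound 3 (0.60 log units; beyond the scatter). Compound 3 is estimated at 60 nM in this assay, within a range from 15 nM to 300 nM.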

Compound 3, half-maximal inhibitory concentration: 5 nM
For compound 3 the middle estimate is 12-fold (1.08 log units) above the measured one, outside the stated range (below it).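

In this assay, among the compounds shown here, the group on the carbonyl carbon of this amide is the first place where one change can be read alone, as the earlier pair differs in more than one place. With 5-methyl-1,2-oxazol-3-yl in place of 4-cyanophenyl, the step is a 3.0-fold lower number from compound 2 to compound 3 (0.48 log units; beyond the scatter), so at this position a five-membered aromatic ring with 2 hetero atoms gives a stronger inhibitor than a six-membered aromatic ring of carbon only, and the nitrile of compound 2 is not needed for a low value. Nothing among the recorded data bears on why this step goes in this direction.

For the compounds shown here, the single step leaves open which part of the new group carries the gain, the ring itself or its methyl, a question that a plain phenyl, or an ethyl or a primary amine in place of that methyl, would bear on. It also leaves open whether the same change on the carbonyl carbon would give a similar step on a different core, such as that of compound 1.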